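The source may report more compounds than this note shows. Statements on the series, on what has been measured and on what is new or still open speak of the compounds shown alone.

Measured compounds:
compound 1, `CCN(CC)CCCCn1c(N)c(-c2nc3ccccc3[nH]2)c2nc(C#N)c(C#N)nc21`: 10100 nM
compound 2, `CN(C)CCCCCn1c(N)c(-c2nc3ccccc3[nH]2)c2nc(C#N)c(C#N)nc21`: 10800 nM
compound 3, `CCN(CC)CCCn1c(N)c(-c2nc3cc(Cl)ccc3[nH]2)c2nc(C#N)c(C#N)nc21`: 24400 nM

Compound 1 and compound 2 share a core and differ by (dimethylamino)methyl in place of diethylamino on a saturated chain carbon, four bonds along the chain from an aromatic nitrogen. In a functional assay on HeLa cells (Homo sapiens) for antiproliferative activity, read by MTT assay, with a stated time of 48 h (a higher number here means a weaker inhibitor, a lower number a stronger inhibitor), compound 1 gives 10100 nM and compound 2 gives 10800 nM; the step is a 1.1-fold higher number from compound 1 to compound 2 (0.03 log units; within the scatter). Compound 3 differs from compound 1 in more than one place, and the difference between the two cores is not broken down here. In this assay compound 3 gives 24400 nM, the highest of the three numbers, beyond the scatter from both compound 1 and compound 2.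

Compound 4, `CN(C)CCCCn1c(N)c(-c2nc3cc(Cl)ccc3[nH]2)c2nc(C#N)c(C#N)nc21`, has not been measured. It differs from compound 3 by (dimethylamino)methyl in place of diethylamino on a saturated chain carbon, three bonds along the chain from an aromatic nitrogen. This is the same kind of change as from compound 1 to compound 2, but not the same: there the place was four bonds along the chain from an aromatic nitrogen, here it is three bonds along the chain from an aromatic nitrogen. Because the earlier step of a 1.1-fold higher number from compound 1 to compound 2 (0.03 log units; within the scatter) stayed within the scatter, a similarly small step is expected here, a 1.0-fold lower number from compound 3 to compound 4 (0.01 log units; within the scatter). Compound 4 is therefore estimated at 24000 nM in this assay, expected between 12000 nM and 48000 nM.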

Compound 4, half-maximal inhibitory concentration: 3120 nM
Compound 4: middle estimate off by 7.7-fold (0.89 log units), on the high side, and the stated range ends above it.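

In this assay, replacing the 3-(diethylamino)propyl group with 4-(dimethylamino)butyl gives a 7.8-fold lower number from compound 3 to compound 4 (0.89 log units; beyond the scatter), and this step does not match the one seen on the other core: the same change on two cores in this assay, a 1.1-fold higher number (0.03 log units; within the scatter) from compound 1 to compound 2 and a 7.8-fold lower number (0.89 log units; beyond the scatter) from compound 3 to compound 4, 8.4-fold (0.92 log units) apart, beyond the scatter of two such steps. The change therefore does not carry over at a fixed size within this series, since the step seen on the core of compound 1 failed to predict the one on the core of compound 3. What it does not show is which difference accounts for the gap, as the two steps differ both in the core and in the place of the change, and each is represented by a single pair.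

The compounds shown leave open how much of the step from compound 3 belongs to the shorter amine substituents and how much to the longer chain, a question a 3-(dimethylamino)propyl group on the same core would address. They also leave open how a cyclic amine such as piperidine or morpholine at the chain end would compare.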